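The source may report more compounds than this note shows. Statements on the series, on what has been measured and on what is new or still open speak of the compounds shown alone.

Notes on the aryloxyacetamide series sharing the core of compound 1 `COc1ccc(NC(=O)COc2c(-c3ccccc3)oc3ccccc3c2=O)cc1`, which in a functional assay on NCI-H661 cells (Homo sapiens) for antiproliferative activity, read by MTT assay, with a stated time of 72 h (on this read-out higher numbers stand for weaker inhibition of growth and lower numbers for stronger inhibition of growth), gives 6740 nM. Compound 2 `O=C(COc1ccc2oc(-c3ccccc3)cc(=O)c2c1)Nc1ccc(F)cc1` in this assay gives 1470 nM. Compound 3 `O=C(COc1ccc2c(=O)c(-c3ccccc3)coc2c1)Nc1ccccc1`, the plain anilide, reaches only a limit of this assay and is reported as > 10000 nM. Compound 3 therefore stands at the limit of > 10000 nM in this assay, at which 1 of the 3 values shown sits, not at a number. Compound 4 `O=C(COc1ccc2c(=O)c(-c3ccccc3)coc2c1)Nc1ccc(-c2ccccc2)cc1` carries phenyl in place of hydrogen on an aromatic carbon. Among the measured compounds shown here, no step between measured compounds is available; compounds 1 and 2 show that a substituted anilide ring can sit at a measurable number, while compound 3 itself gives only a limit, so the size of the change cannot be fixed from the data. The step from compound 3 to compound 4 is expected to be an at least 1.4-fold lower number from compound 3 to compound 4 (0.15 log units; that floor lies within the scatter), modest and toward stronger inhibition at most. Compound 4 is estimated at 7000 nM, between 1800 nM and 30000 nM, with a real chance of another limit.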

Compound 4, concentration for 50% growth inhibition: > 10000 nM
Compound 4 gave a limit, no number; the forecaster's own chance of this, stated with the estimate: 40%; middle value at least 1.4-fold (0.15 log units) away from the limit.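

Among the compounds shown here, compound 3 and compound 4 both end at a limit in this assay, so no step between them can be read: the limit of > 10000 nM in this assay, at which 2 of the 4 values shown sit.

Whether phenyl in place of hydrogen on this aromatic carbon changes growth inhibition at all stays open in the compounds shown.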